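A Second Acetyl on an Inactive Compound

The source may hold more compounds than are shown below. What is called first, only, known or untested is meant among the compounds shown, and "the series" means these compounds.

In a functional assay on A549 cells (Homo sapiens) for cytotoxicity (a higher number here means a weaker inhibitor, a lower number a stronger inhibitor), compound 1 `CCCC[C@H](C)[C@H](OC(N)=O)[C@@H](C)[C@H](O)[C@@H](C)C/C(C)=C\[C@H](C)[C@@H](O)[C@@H](C)CC[C@@H](O)C[C@@H]1OC(=O)[C@H](C)[C@@H](O)[C@H]1C` gives 67.7 nM and compound 3 `C=C/C=C\[C@H](C)[C@H](OC(N)=O)[C@@H](C)[C@H](O)[C@@H](C)C/C(C)=C\[C@H](C)[C@@H](O)[C@@H](C)/C=C\[C@@H](O)C[C@@H]1OC(=O)C(C)=C[C@H]1C` gives 21.7 nM. Compound 2 `C=C/C=C\[C@H](C)[C@H](OC(N)=O)[C@@H](C)[C@H](OC(C)=O)[C@@H](C)C/C(C)=C\[C@H](C)[C@@H](O)[C@@H](C)/C=C\[C@@H](O)C[C@@H]1OC(=O)C(C)=C[C@H]1C` returns only a limit, > 8100 nM, and so stands at the limit of > 8100 nM in this assay, at which 1 of the 3 values shown sits.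

Compound 4 `C=C/C=C\[C@H](C)[C@H](OC(N)=O)[C@@H](C)[C@H](OC(C)=O)[C@@H](C)C/C(C)=C\[C@H](C)[C@@H](OC(C)=O)[C@@H](C)/C=C\[C@@H](O)C[C@@H]1OC(=O)C(C)=C[C@H]1C` departs from compound 2 by acetyl in place of hydrogen on an oxygen on a saturated carbon, hydroxy to acetoxy. Among the measured compounds shown here, one measured step bears on this change. It runs the same kind of change the other way at a different oxygen, hydrogen in place of acetyl, and it gave an at least 370-fold lower number from compound 2 to compound 3 (2.57 log units; beyond the scatter).

With that large step in view, no recovery is expected from a second acetyl. The number in this assay should instead stay where it is or rise, and the assay may well report a limit again. The expected change is small and upward, a step that the limit leaves unreadable from compound 2 to compound 4. For compound 4 the estimated value is 12000 nM, with an expected range of 8100 nM to 40000 nM.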

Compound 4, half-maximal inhibitory concentration: > 7580 nM
Compound 4 gave a limit, no number (the forecaster's own chance of this, stated with the estimate: 75%); the middle value does not contradict the limit.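

In this assay compound 4 gives only a limit, > 7580 nM. Among the compounds shown here, compound 2 also gives only a limit, > 8100 nM, so no step between compound 2 and compound 4 can be read. Going by these compounds, whether the second acetyl changes the number at all remains open.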